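A chalcone series at the assay ceiling on liver cells

A few compounds are considered here, and "the series" means these few. Any claim that something is new, unique, unknown or untested is made for them only; others in the source may bear on it.

Compound 1, with structure `COc1ccc(C(=O)/C=C/c2ccc(F)cc2)c2c1C=CC(C)(C)O2`, is tested in a functional assay on HepG2 cells (Homo sapiens) for antiproliferative activity, read by MTT assay, with a stated time of 24 h; on this read-out lower numbers stand for stronger inhibition and higher numbers for weaker inhibition. In this assay compound 1 returns only a limit, > 10000 nM, not a measured number. Two close relatives share its core. Compound 2, `COc1ccc(C(=O)/C=C/c2ccc(-c3ccccc3)cc2)c2c1C=CC(C)(C)O2`, carries phenyl in place of fluoro on an aromatic carbon, and in this assay compound 2 likewise gives a limit, > 10000 nM. Compound 3, `COc1ccc(C(=O)/C=C/c2ccc(-n3ccnc3)cc2)c2c1C=CC(C)(C)O2`, carries 1H-imidazol-1-yl in place of fluoro on an aromatic carbon, and in this assay compound 3 also gives a limit, > 10000 nM. The steps between them, a step that the two limits leave unreadable from compound 1 to compound 2, a step that the two limits leave unreadable from compound 1 to compound 3 and a step that the two limits leave unreadable from compound 2 to compound 3, cannot be sized, since every value sits at the limit of > 10000 nM in this assay, at which 3 of the 3 values shown sit.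

Compound 4, `COc1ccc(C(=O)/C=C/c2ccco2)c2c1C=CC(C)(C)O2`, differs from compound 1 in another place: furan-2-yl in place of 4-fluorophenyl on a double-bonded chain carbon bound to a double-bonded chain carbon. Going by the values given here, none of the measured steps touches the position that changes here, so they bear on it only by showing that nothing in this set has yet produced a readable number. With compound 1 standing at a limit, no direction of change can be read, and the step that the limit leaves unreadable from compound 1 to compound 4 is therefore an estimate only. Compound 4 is expected to give about 20000 nM, with a range from 4000 nM to 100000 nM, and most likely to be reported as a limit again.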

Compound 4, half-maximal inhibitory concentration: > 10000 nM
Compound 4 ended at the assay's limit; the forecaster's own chance of this, stated with the estimate: 75%; the middle value is on the limit's open side.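

In this assay compound 4 gives > 10000 nM, which is a limit and not a number. The step between compound 1 and compound 4 therefore cannot be read, and every value shown stands at the same limit: the limit of > 10000 nM in this assay, at which 4 of the 4 values shown sit.

The compounds shown leave open whether any change to the shared core would give a readable number in this assay.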